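The source may report more compounds than this note shows. Statements on the series, on what has been measured and on what is new or still open speak of the compounds shown alone.

In an ADME assay on CCRF-HSB-2 cells (Homo sapiens) for cytotoxicity, with a stated time of 7 days (on this read-out lower numbers stand for higher toxicity in this test and higher numbers for lower toxicity in this test), compound 1 `Nc1nc(NCc2ccccc2)c2ncn(/C=C3/CC3(CO)CO)c2n1` gives > 20000 nM, which is a limit of the assay.
In this assay compound 2 `CC(C)Nc1nc(N)nc2c1ncn2/C=C1/CC1(CO)CO` gives > 20000 nM, again a limit of the assay.
In this assay compound 3 `CCCCCCCCSc1nc(N)nc2c1ncn2/C=C1/CC1(CO)CO` gives 60000 nM.

These three compounds share a core and differ only in the group carried on one aromatic carbon. Compound 3 is the only one of them with a number in this assay; the other two values are limits. For that reason none of the steps between them can be sized: a step that the two limits leave unreadable from compound 1 to compound 2, a step that the limit leaves unreadable from compound 1 to compound 3 and a step that the limit leaves unreadable from compound 2 to compound 3 all stay unreadable because of the limit of > 20000 nM in this assay, at which 2 of the 3 values shown sit.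

Compound 4 `Nc1nc(SCc2ccccc2)c2ncn(/C=C3/CC3(CO)CO)c2n1` is reached from compound 3 by phenyl in place of heptyl on a saturated chain carbon bound to a sulfur. Going by the values given here, no measured step makes this kind of exchange, and the two steps that end at compound 3 replace an amino-linked group with octylsulfanyl without a readable size. With nothing to set a direction, the step is expected to stay within scatter, so a 1.3-fold lower number from compound 3 to compound 4 (0.12 log units; within the scatter) is the estimate. Compound 4 is therefore expected to give about 45000 nM, between 15000 nM and 130000 nM, with a fair chance that only a limit is reported.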

Compound 4, half-maximal cytotoxic concentration: > 100000 nM
Compound 4: no number, only a limit (the forecaster's own chance of this, stated with the estimate: 55%); middle value at least 2.2-fold (0.34 log units) away from the limit.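

In this assay compound 4 gives > 100000 nM, which is a limit of the assay and not a number. Going by these compounds alone, its change, phenyl in place of heptyl on a saturated chain carbon bound to a sulfur, gives the first step in this set with any readable size, and that step is an at least 1.6-fold higher number from compound 3 to compound 4 (0.22 log units; that floor lies within the scatter). This is only a floor that lies within the scatter, so it shows that exchanging octylsulfanyl for benzylsulfanyl did not bring the number down, but not how large the real step is, and the steps that reach compound 4 from the two amino-linked compounds cannot be read.

From the compounds shown here alone, it stays open how far compound 4 really lies from compound 3, and whether the sulfur link or the amino link makes any difference when the group it carries is the same, since that comparison rests on limits alone. Going by these compounds, how a shorter chain such as butylsulfanyl, or a benzylsulfanyl group with a chlorine on its ring, would read in this assay also remains open.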